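Rearranging the Side Chain of Compound 2

This account rests on a few compounds, and the source may have more. Where it says the series, first, only, none or still open, it means among the compounds named here.

In an ADME assay on CHO cells (Cricetulus griseus) for cytotoxicity, read by MTT assay (a higher number here means that more compound is tolerated, a lower number that less compound is tolerated), compound 2 (`CN1CCN(C2CCN(c3nccc4[nH]c(-c5cc(F)cc(F)c5)nc34)CC2)CC1`) gives 30000 nM. Compound 3 (`COC(=O)c1cccc(-c2nc3c(N4CCC(N5CCN(C)CC5)CC4)nccc3[nH]2)c1`) gives 34000 nM, and a 1.1-fold higher number from compound 2 to compound 3 (0.05 log units; within the scatter) leaves the two level. Compound 1 (`CN1CCN(C2CCN(c3nccc4[nH]c(-c5cccc(OC(F)(F)F)c5)nc34)CC2)CC1`) gives 3000 nM and stands alone at the low end of the series: a 10-fold higher number from compound 1 to compound 2 (1.00 log units; beyond the scatter), and an 11-fold higher number from compound 1 to compound 3 (1.05 log units; beyond the scatter).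

Compound 4 (`Fc1cc(F)cc(-c2nc3c(N4CCC(CN5CCNCC5)CC4)nccc3[nH]2)c1`) keeps the 3,5-difluorophenyl of compound 2 and changes elsewhere: (piperazin-1-yl)methyl in place of 4-methylpiperazin-1-yl on a saturated ring carbon. Here (piperazin-1-yl)methyl stands in place of 4-methylpiperazin-1-yl on a saturated ring carbon, and the two structures have the same atoms, joined differently.

For the measured compounds named here, none of the measured steps touches this part of the molecule. All of them exchange the group on an aromatic carbon, so they say nothing direct about the new change. Going by the values given here, the only guide is the group that compound 4 retains: compound 2, which carries it, gives 30000 nM, and no step beyond the scatter can be argued for in either direction. The expected change is small, namely a 1.2-fold lower number from compound 2 to compound 4 (0.08 log units; within the scatter). The data hold no measured variation of this side chain, so the range is kept wide. For compound 4 the estimated value is 25000 nM, with an expected range from 8000 nM to 60000 nM.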

Compound 4, half-maximal cytotoxic concentration: 20000 nM
Beside the measured number, compound 4's estimate is 1.3-fold (0.10 log units) above it; the measured number falls inside the stated range.
By their numbers in this assay, from the lowest: compound 1; then compounds 4, 2 and 3 (each within the scatter of the next).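

For the compounds shown here, this is the first variation at the saturated ring carbon; every earlier step exchanged a group on an aromatic carbon. With the 3,5-difluorophenyl group held constant, putting (piperazin-1-yl)methyl in place of 4-methylpiperazin-1-yl adds a hydrogen-bond donor while keeping the same atoms, and this assay shows a 1.5-fold lower number from compound 2 to compound 4 (0.18 log units; within the scatter), so the two compounds stand level and this rearrangement joins the exchange of compound 2 for compound 3 as a step inside the scatter. No evidence is available that bears on why the rearrangement leaves the number level.

The step alters the linkage and the place of the methyl carbon together, so the compounds shown do not separate these two changes, which a (4-methylpiperazin-1-yl)methyl or a plain piperazin-1-yl group would address. From the compounds shown here alone, it also remains open whether the same rearrangement would stay level alongside the 3-(trifluoromethoxy)phenyl group of compound 1, and what a simple dimethylamino group or a longer chain to the piperazine would do at this saturated ring carbon.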